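The compounds below may be only part of what the source reports. "The series", "measured", "known", "first", "only" and "open" are said of these compounds alone.

Compound 1 `CN(C)CCn1cnnc1-c1cc(Oc2ccc(NC(=O)N/N=C/c3c(Cl)cccc3Cl)cc2F)ccn1` carries a 2,6-dichlorophenyl on a carbon with a double bond to nitrogen. In a functional assay on HT-29 cells (Homo sapiens) for cytotoxicity, read by MTT assay, with a stated time of 72 h (on this read-out lower numbers stand for stronger inhibition and higher numbers for weaker inhibition), compound 1 gives 280 nM, the lowest number among the three measured compounds. Compound 2 `CN(C)CCn1cnnc1-c1cc(Oc2ccc(NC(=O)N/N=C/c3c[nH]c4ccccc34)cc2F)ccn1`, which bears an indolyl group at the same place, gives 1300 nM in this assay, and the step from compound 1 to compound 2 is a 4.6-fold higher number from compound 1 to compound 2 (0.67 log units; beyond the scatter). Compound 3 `CN(C)CCn1cnnc1-c1cc(Oc2ccc(NC(=O)N/N=C/c3cc(C(C)(C)C)cc(C(C)(C)C)c3O)cc2F)ccn1`, with a di-tert-butyl hydroxyphenyl at that position, gives 680 nM in this assay, again a higher number than compound 1. Compound 4 `COc1ccc(/C=N/NC(=O)Nc2ccc(Oc3ccnc(-c4nncn4CCN(C)C)c3)c(F)c2)c(OC)c1` has not yet been measured; it differs from compound 1 in that (2,4-dimethoxyphenyl in place of 2,6-dichlorophenyl on a carbon with a double bond to nitrogen). Among the compounds with values here, the only step that bears on this change is the one from compound 1 to compound 2, which is modest and beyond the scatter, and compound 3 points the same way. A modest rise in this assay is therefore expected for compound 4, of about a 2.1-fold higher number from compound 1 to compound 4 (0.33 log units; beyond the scatter). The value for compound 4 in this assay is estimated at 600 nM, within a range of 250 nM to 1500 nM.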

Compound 4, half-maximal inhibitory concentration: 1780 nM
Compound 4: middle estimate off by 3.0-fold (0.47 log units), on the low side; the measured number lies above the stated range.
By their numbers in this assay, from the lowest: compound 1; then compounds 3, 2 and 4 (each within the scatter of the next, the first and the last beyond it).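

In this assay the step of a 6.4-fold higher number from compound 1 to compound 4 (0.80 log units; beyond the scatter) shows that the rise at this position does not depend on leaving the phenyl type, since 2,6-dichlorophenyl and 2,4-dimethoxyphenyl are both a six-membered aromatic ring of carbon only. The step of a 1.4-fold higher number from compound 2 to compound 4 (0.14 log units; within the scatter) adds that 2,4-dimethoxyphenyl and 1H-indol-3-yl cannot be told apart here, although the two groups differ in kind. No measurement shown accounts for these differences at this position.

The compounds shown leave open whether the low number of compound 1 rests on the chlorine atoms themselves, as a plain phenyl or a phenyl carrying one chlorine would test. They also leave open how a ring bearing a dimethylamino group or a carboxylic acid would behave on this carbon.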